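Methyl on the imidazole ring and a whole-animal antagonist readout

The compounds below may be only part of what the source reports. "The series", "measured", "known", "first", "only" and "open" are said of these compounds alone.

Measured so far:
compound 1, `CC(=O)N(C)C(C)C#CCn1ccnc1`, > 100 mg/kg (a limit)
compound 2, `CC(=O)N(C)C(C)C#CCn1ccnc1C`, 11.8 mg/kg
compound 3, `COC(=O)N(C)CC#CCn1ccnc1`, > 100 mg/kg (a limit)

All three were tested in a functional assay on the whole organism for antagonist activity, with Mus musculus as the target; on this read-out higher numbers stand for an effect only at larger amounts of compound and lower numbers for an effect already at smaller amounts. For compound 1 the value > 100 mg/kg is a limit of the assay and not a number. Compound 2 gives 11.8 mg/kg in this assay. The difference between the two is methyl in place of hydrogen on an aromatic carbon, and the step of an at least 8.4-fold lower number from compound 1 to compound 2 (0.92 log units; beyond the scatter) is a clear one. For compound 3 the value > 100 mg/kg is again a limit and not a number; it shares that position with compound 1, as the limit of > 100 mg/kg in this assay, at which 2 of the 3 values shown sit, shows. How the core of compound 3 differs from the core of compound 1 is not broken down here.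

Compound 4, `COC(=O)N(C)CC#CCn1cncc1C`, has not yet been measured. It differs from compound 3 by methyl in place of hydrogen on an aromatic carbon. Within the data shown here, this is the same kind of change as the one from compound 1 to compound 2, but not the same: there the methyl sits between two ring nitrogen atoms, whereas in compound 4 it sits next to the ring nitrogen and two ring bonds from the ring nitrogen, in both cases next to the ring atom that bears a large group.

Resting on the step of an at least 8.4-fold lower number from compound 1 to compound 2 (0.92 log units; beyond the scatter), and allowing for the changed place and the different core, compound 4 is expected to show a step of about an at least 1.6-fold lower number from compound 3 to compound 4 (0.22 log units; that floor lies within the scatter) in this assay. The estimate for compound 4 in this assay is 60 mg/kg, with a likely range from 15 mg/kg to 300 mg/kg, and there is a fair chance that only a limit is reported again.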

Compound 4, dose for half-maximal effect: > 100 mg/kg
Compound 4: a limit, no number (the forecaster's own chance of this, stated with the estimate: 50%); middle value at least 1.6-fold (0.22 log units) from the limit.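

In this assay compound 4 gives > 100 mg/kg, a limit of the assay and not a number. Compound 3 also sits at a limit, so no step between compound 3 and compound 4 can be read, and both share the same limit: the limit of > 100 mg/kg in this assay, at which 3 of the 4 values shown sit.

The compounds shown leave open whether methyl in place of hydrogen on an aromatic carbon changes the read-out at all on the core of compound 3.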